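This account rests on a few compounds, and the source may have more. Where it says the series, first, only, none or still open, it means among the compounds named here.

Of the compounds shown here, two have so far been measured in an assay on L cells for inhibition of Protein-serine O-palmitoleoyltransferase porcupine (Mus musculus), read by reporter gene assay, with a stated time of 24 h; on this read-out higher numbers stand for an effect only at larger amounts of compound and lower numbers for an effect already at smaller amounts. Compound 1 `COc1ccc(-n2c(SCC(=O)Nc3nc4ccc(Cl)cc4s3)nc3c(c2=O)SCC3)cc1` gives 35 nM, while compound 2 `O=C(CSc1nc2c(c(=O)n1-c1ccc(F)cc1)SCC2)Nc1nc2ccc(C(F)(F)F)cc2s1` gives 100 nM, the higher of the two numbers and beyond the scatter from compound 1. Compound 3 `O=C(CSc1nc2c(c(=O)n1-c1ccc(F)cc1)SCC2)Nc1nc2ccc(Cl)cc2s1` is built from compound 2 by one change: chloro in place of trifluoromethyl on an aromatic carbon. For the measured compounds named here, compound 1 also carries chloro there but differs in a second place as well, so no single measured step sets the size. Compound 3 is expected to move toward compound 1 by a modest step of a 1.8-fold lower number from compound 2 to compound 3 (0.26 log units; within the scatter), with an estimated 55 nM and a range from 20 nM to 150 nM.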

Compound 3, half-maximal effective concentration: 175 nM
For compound 3 the middle estimate is 3.2-fold (0.50 log units) below the measured one; the whole stated range lies below it.
By their numbers in this assay, from the lowest: compound 1; then compounds 2 and 3 (each within the scatter of the next).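

Chloro in place of trifluoromethyl on this aromatic carbon gives a 1.8-fold higher number from compound 2 to compound 3 (0.24 log units; within the scatter) and so the read-out does not separate these two groups here. Fluoro in place of methoxy on an aromatic carbon gives a 5.0-fold higher number from compound 1 to compound 3 (0.70 log units; beyond the scatter) and so, among these compounds, the larger step comes with the methoxy-to-fluoro change. Nothing available explains either step.

Still open, as far as these compounds go, is how a smaller or different group on the first aromatic carbon, such as a methyl, a nitrile or plain hydrogen, would read. Also open, from the compounds shown here alone, is how an ethoxy group would compare with methoxy.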